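The source may hold more compounds than are shown below. What is called first, only, known or untested is meant among the compounds shown, and "the series" means these compounds.

Cytotoxicity series, read-out a functional assay on A549 cells (Homo sapiens) for cytotoxicity, read by trypan blue exclusion, with a stated time of 48 h; on this read-out lower numbers stand for stronger inhibition and higher numbers for weaker inhibition; measured so far:

compound 1 `Cc1ccc(-c2csc(NC(=O)COc3ccc(Cl)c(C)c3)n2)cc1`: 44500 nM
compound 2 `Cc1ccc(-c2csc(NC(=O)COc3ccccc3C)n2)cc1`: 50100 nM
compound 3 `Cc1ccccc1OCC(=O)Nc1nc(-c2ccc(Cl)cc2)cs1`: 64800 nM

All three numbers sit close together. Compound 2 holds the second highest of the three, with compound 1 nearest and compound 3 furthest, and both of those gaps are within the scatter. The two single-point changes measured so far are a 1.1-fold higher number from compound 1 to compound 2 (0.05 log units; within the scatter) and a 1.3-fold higher number from compound 2 to compound 3 (0.11 log units; within the scatter); neither moves the number beyond what repeat measurements would give.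

Compound 4 `Cc1ccc(OCC(=O)Nc2nc(-c3ccc(C)cc3)cs2)cc1` is not yet measured. It differs from compound 2 by 4-methylphenyl in place of 2-methylphenyl on an oxygen on a saturated carbon. The step from compound 1 to compound 2 is the one that bears directly on this, since it also swaps the aryl group on the same oxygen on a saturated carbon, and it stayed within the scatter; the step from compound 2 to compound 3 changed the other ring and likewise stayed within the scatter. Going by the values given here, no step in this set has moved this assay beyond the scatter, so no step beyond the scatter is expected here either, in either direction.

The expected step is a 1.0-fold lower number from compound 2 to compound 4 (0.00 log units; within the scatter). Compound 4 is therefore estimated at 50000 nM, with a range of 25000 nM to 100000 nM.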

Compound 4, half-maximal inhibitory concentration: 48800 nM
Beside the measured number, compound 4's estimate is 1.0-fold (0.01 log units) above it, and the stated range covers the measured number.
By their numbers in this assay, from the lowest: compounds 1, 4, 2 and 3 (each within the scatter of the next).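

In this assay, 4-methylphenyl in place of 2-methylphenyl on an oxygen on a saturated carbon gives a 1.0-fold lower number from compound 2 to compound 4 (0.01 log units; within the scatter) and stays within the scatter, so moving the methyl around this aryl ring, with the atoms unchanged, has no readable effect here. The replacement of 4-chloro-3-methylphenyl by 4-methylphenyl at the same place gives a 1.1-fold higher number from compound 1 to compound 4 (0.04 log units; within the scatter) and also stays within the scatter, so compounds 1, 2 and 4 now form a set of three aryl groups at this position with no step beyond the scatter. No measurement at hand speaks to the reason for this result.

Every aryl group at this place carries only methyl or chloro. From the compounds shown here alone, whether an amine or a carboxylic acid on that ring, or a longer chain in place of its methyl, would move the number beyond the scatter remains open.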